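This account rests on a few compounds, and the source may have more. Where it says the series, first, only, none or still open, it means among the compounds named here.

Measured in a functional assay on NCI-H460 cells (Homo sapiens); a higher number here means that more compound is needed for the effect, a lower number that less compound is needed:
- compound 1 `COc1cc(C2OC(c3ccccc3N(C)C)=NN2C(C)=O)cc(OC)c1OC`: 109 uM
- compound 2 `COc1ccc(C2OC(c3ccc(N(C)C)cc3)=NN2C(C)=O)c(OC)c1OC`: 6.8 uM
- compound 3 `CCOC(=O)C(=O)N1N=C(c2ccc(N(C)C)cc2)OC1c1cc(OC)c(OC)c(OC)c1`: 33 uM

In this assay, compound 3 stands in the middle of the three. Compound 1 gives a higher number and compound 2 a lower one, and both gaps lie beyond the usual scatter. No two of these compounds differ in only one place, so the data contain no measured step that isolates a single change.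

The next compound is compound 4 `COc1cc(C2OC(c3ccc(N(C)C)cc3)=NN2C(=O)CN)cc(OC)c1OC`. It keeps the rest of compound 3 but carries aminomethyl in place of ethoxycarbonyl on a carbonyl carbon.

The closest guides are weak. Compound 2 carries a small methyl group on that carbonyl and gives 6.8 uM, which suggests that a smaller group could lower the number. Compound 1 goes against this: it carries the same methyl group yet gives 109 uM. Both also differ from compound 4 elsewhere, so only a small shift towards a lower number is expected, and it may not exceed the scatter.

The expected change is a 1.8-fold lower number from compound 3 to compound 4 (0.26 log units; within the scatter).

For compound 4 the estimate is 18 uM, with an expected range of 5 uM to 60 uM.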

Compound 4, concentration for half-maximal effect: 0.66 uM
The estimate for compound 4 lay 27-fold (1.44 log units) above the measured number; measured number below the stated range.
By their numbers in this assay, from the lowest: compound 4; then compound 2; then compound 3; then compound 1.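

In this assay, replacing ethoxycarbonyl with aminomethyl on the carbonyl carbon attached to the ring's amide-type nitrogen gives a 50-fold lower number from compound 3 to compound 4 (1.70 log units; beyond the scatter), a large step well beyond the scatter. Among the compounds shown here, this is the first measured step that isolates a single change, and it shows that the number in this assay depends strongly on the group at this place, which the earlier compounds could not show because each of them differs from the others in more than one place. The swap changes several things at once, with 5 heavy atoms and no hydrogen-bond donor leaving, and 2 heavy atoms and 1 hydrogen-bond donor entering, and no measurement shown here explains why the number falls.

From the compounds shown here alone, it remains open whether the step depends on the amine nitrogen or on the shorter group, since one pair of compounds cannot separate the two. Hydroxymethyl, dimethylaminomethyl or a longer aminoethyl chain at this place on the core of compound 4 would help to tell these readings apart.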